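The compounds below may be only part of what the source reports. "The series", "measured", "known", "first", "only" and "open" are said of these compounds alone.

Measured so far:
Compound 1, `O=C1/C(=C/c2ccccc2F)CN(S(=O)(=O)c2ccc(Cl)cc2)C/C1=C\c1ccccc1F`: in an ADME assay on L02 cells (Homo sapiens) for cytotoxicity, read by MTT assay, with a stated time of 24 h (a lower number here means a stronger inhibitor, a higher number a weaker inhibitor), compound 1 gives 14100 nM.
Compound 2, `Cc1ccc(S(=O)(=O)N2C/C(=C\c3cccc(F)c3)C(=O)/C(=C/c3cccc(F)c3)C2)cc1`: in this assay compound 2 gives 15700 nM.

Both compounds share the same core, a ring bearing a sulfonyl-linked aromatic group and two fluorinated benzylidene arms. The two numbers lie within the usual scatter of each other, so compound 2 cannot be set apart from compound 1 on these data; it simply stands at a similar level.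

Compound 3, `CC(=O)Nc1ccc(S(=O)(=O)N2C/C(=C\c3cccc(F)c3)C(=O)/C(=C/c3cccc(F)c3)C2)cc1`, is the next compound, not yet measured in this assay. It differs from compound 2 in one place: acetamido in place of methyl on an aromatic carbon. Put simply, acetamido takes the place of methyl on an aromatic carbon of the sulfonyl-linked ring, so that 4-methylphenyl becomes 4-acetamidophenyl.

For the measured compounds named here, no step between measured compounds that shows the effect of such a change is available. With only that, the expected step is a 1.0-fold higher number from compound 2 to compound 3 (0.01 log units; within the scatter), none beyond the scatter. Compound 3 is therefore expected to give about 16000 nM in this assay, with a plausible range from 7000 nM to 36000 nM.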

Compound 3, half-maximal inhibitory concentration: 17500 nM
Beside the measured number, compound 3's estimate is 1.1-fold (0.04 log units) below it; low and high end bracket the measured number.
By their numbers in this assay, from the lowest: compounds 1, 2 and 3 (each within the scatter of the next).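

Going from 4-methylphenyl to 4-acetamidophenyl gives a 1.1-fold higher number from compound 2 to compound 3 (0.05 log units; within the scatter) in this assay, the first step here that isolates a change at this position. On this aromatic carbon, para to a large group, acetamido brings more heavy atoms than methyl, along with a hydrogen-bond donor and a hydrogen-bond acceptor, yet compound 3 cannot be told apart from compound 2 in this cell-based read-out. For the compounds shown here, no measured information is available to explain this outcome, so the pair records only that the swap left no change that can be read beyond the usual scatter.

This single pair does not show whether the same holds for other groups at this position, such as an amine, a carboxylic acid or a longer chain like butyl. It also leaves open whether an acetamido group would behave in the same way on a compound with different arms, such as those of compound 1, which differs from compound 3 in more than one place and so offers no clean comparison.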